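Aryl variation on the saturated ring carbon, growth inhibition

The source may hold more compounds than are shown below. What is called first, only, known or untested is meant among the compounds shown, and "the series" means these compounds.

Measured so far:
compound 1 `Cc1cc(O)c(C2=NN(c3ccc(S(N)(=O)=O)cc3)C(c3ccccc3Cl)C2)cc1Cl` gives 10300 nM
compound 2 `Cc1cc(O)c(C2=NN(c3ccc(S(N)(=O)=O)cc3)C(/C=C/c3ccccc3)C2)cc1Cl` gives 14700 nM

Both values come from a functional assay on T47D cells (Homo sapiens) for antiproliferative activity, with a stated time of 48 h; a lower number here means a stronger inhibitor of growth, a higher number a weaker inhibitor of growth. Compound 2 has the higher of the two numbers, but the step of a 1.4-fold higher number from compound 1 to compound 2 (0.15 log units; within the scatter) lies within the scatter, so the two compounds are not separated. Compound 3 `COc1ccc(C2CC(c3cc(Cl)c(C)cc3O)=NN2c2ccc(S(N)(=O)=O)cc2)cc1OC` differs from compound 2 by 3,4-dimethoxyphenyl in place of 2-phenylethenyl on a saturated ring carbon. Going by the values given here, the one step that bears on this position, a 1.4-fold higher number from compound 1 to compound 2 (0.15 log units; within the scatter), was within the scatter, so no shift beyond the scatter is expected in this assay. For compound 3 the expected step is a 1.2-fold lower number from compound 2 to compound 3 (0.09 log units; within the scatter). Compound 3 is estimated at 12000 nM, with a range from 5000 nM to 30000 nM.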

Compound 3, concentration for total growth inhibition: 13300 nM
Compound 3: the middle estimate sits 1.1-fold (0.04 log units) below what was measured; low and high end bracket the measured number.
By their numbers in this assay, from the lowest: compounds 1, 3 and 2 (each within the scatter of the next).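

In this assay the change to 3,4-dimethoxyphenyl gives a 1.1-fold lower number from compound 2 to compound 3 (0.04 log units; within the scatter) and a 1.3-fold higher number from compound 1 to compound 3 (0.11 log units; within the scatter), so neither step separates the compounds. Going by these compounds alone, on this saturated ring carbon, a substituted phenyl carrying hydrogen-bond acceptors is therefore not distinguished from 2-phenylethenyl or 2-chlorophenyl, which extends the flat picture from the first pair to three groups. No measurement here offers an explanation for this flatness. Still open, as far as these compounds go, is whether a group of another kind at this position, such as an amine, a carboxylic acid or a longer alkyl chain, would move the number beyond the scatter.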